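Formyl to carboxy on the shared core

A few compounds are considered here, and "the series" means these few. Any claim that something is new, unique, unknown or untested is made for them only; others in the source may bear on it.

In an ADME assay on NIH3T3 cells (Mus musculus) for cytotoxicity, read by sulforhodamine B assay, with a stated time of 96 h (a higher number here means that more compound is needed for the effect, a lower number that less compound is needed), compound 1 (`CCCC(=O)CC/C=C/C=C/C#CC#C/C=C/COC(C)=O`) gives 14200 nM and compound 2 (`CCCC(=O)CC/C=C/C=C/C#CC#C/C=C/COC(=O)CCl`) gives 11900 nM, while compound 3 (`CCCC(=O)CC/C=C/C=C/C#CC#C/C=C/C=O`) gives 13200 nM and sits within the scatter of both. Compound 4 (`CCCC(=O)CC/C=C/C=C/C#CC#C/C=C/C(=O)O`) differs from compound 3 in one place, with hydroxy in place of hydrogen on a carbonyl carbon, so that formyl becomes carboxy (hydroxy in place of hydrogen on a carbonyl carbon). Among the compounds with values here, no measured step makes this exact change. The closest evidence is the pair of steps that bring in the formyl group, a 1.1-fold lower number from compound 1 to compound 3 (0.03 log units; within the scatter) and a 1.1-fold higher number from compound 2 to compound 3 (0.05 log units; within the scatter), both small. The chloro change, a 1.2-fold lower number from compound 1 to compound 2 (0.08 log units; within the scatter), is also small and lies within the scatter. Three compounds are a thin basis, and none of them carries a carboxy group, so a wide range is kept. On these flat steps, the expected change is a 1.1-fold higher number from compound 3 to compound 4 (0.06 log units; within the scatter), with no direction expected beyond the scatter. For compound 4 the estimated value is 15000 nM, with an expected range from 7000 nM to 40000 nM.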

Compound 4, half-maximal effective concentration: > 30000 nM
Compound 4 was reported as a limit (the forecaster's own chance of this, stated with the estimate: 10%); at least 2.0-fold (0.30 log units) between middle value and limit.
By their numbers in this assay, from the lowest: compounds 2, 3 and 1 (each within the scatter of the next). At a limit, above all of these: compound 4.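

Hydroxy in place of hydrogen on this carbonyl carbon is the first change in the series to go beyond the scatter in this assay, with an at least 2.2-fold higher number from compound 3 to compound 4 (0.35 log units; beyond the scatter). The earlier exchanges among acetoxymethyl, (((chloromethyl)carbonyl)oxy)methyl and formyl left the numbers within the scatter of one another, yet carboxy in place of either of the two longer groups also goes beyond it, with an at least 2.1-fold higher number from compound 1 to compound 4 (0.32 log units; beyond the scatter) and an at least 2.5-fold higher number from compound 2 to compound 4 (0.40 log units; beyond the scatter), so this end of the shared core does respond to change. For compound 4 the reading is a limit of the assay and not a number, and it is the only limit in the set: the limit of > 30000 nM in this assay, at which 1 of the 4 values shown sits.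

As far as these compounds go, how far the number of compound 4 lies past that limit stays open, so the three steps fix only a floor on the size of the change. Also open, from the compounds shown here alone, is whether the shift depends on the hydroxy itself, which a methyl ester or a primary amide on the same carbonyl carbon would test, and whether a carboxy group behaves the same way on a longer chain.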